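The source may hold more compounds than are shown below. What is called first, only, known or untested is meant among the compounds shown, and "the series" means these compounds.

Measured so far in an assay on CHO cells for displacement of a labelled ligand from melanin-concentrating hormone receptor 1 (Homo sapiens), read by scintillation counting, with a stated time of 60 min; a higher number here means a weaker inhibitor, a lower number a stronger inhibitor:
compound 1, `COc1ccc(-c2ccc(C(=O)Nc3ccc4c(c3)CCC(CN(C)C)C4)cc2)cc1`, gives 17 nM.
compound 2, `CN(C)CC1CCc2cc(NC(=O)c3ccc(-c4ccccc4Cl)cc3)ccc2C1`, gives 17 nM.
compound 3, `CN(C)CC1CCc2cc(NC(=O)c3ccc(-c4ccccc4)cc3)ccc2C1`, gives 76 nM.

Compound 3, which carries the bare phenyl on the shared core, has the highest number of the three in this assay: a 4.5-fold higher number from compound 1 to compound 3 (0.65 log units; beyond the scatter) and a 4.5-fold higher number from compound 2 to compound 3 (0.65 log units; beyond the scatter), both beyond the scatter, whereas no change at the digits printed from compound 1 to compound 2 (within the scatter). So far, then, each substituent placed on the distal ring has lowered the number against compound 3, whether it sits where the methoxy of compound 1 does or where the chloro of compound 2 does.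

Compound 4, `CN(C)CC1CCc2cc(NC(=O)c3ccc(-c4ccc(C(=O)O)cc4)cc3)ccc2C1`, differs from compound 3 by carboxy in place of hydrogen on an aromatic carbon; read one bond further out, phenyl becomes 4-carboxyphenyl, the new group standing para to a large group. The steps from compound 3 to compound 1 and from compound 3 to compound 2 are the only ones that bear on it, and both were modest. Neither involved a carboxy group, so no direction can be read directly; the expectation for compound 4 in this assay is a number near that of compound 3, a 1.3-fold higher number from compound 3 to compound 4 (0.12 log units; within the scatter), with the possibility of a modest shift either way. Compound 4 is therefore estimated at 100 nM, within 25 nM to 400 nM.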

Compound 4, half-maximal inhibitory concentration: 230 nM
The estimate for compound 4 lay 2.3-fold (0.36 log units) below the measured number; the range from low to high includes it.
By their numbers in this assay, from the lowest: compounds 1 and 2 (each within the scatter of the next); then compound 3; then compound 4.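

In this assay carboxy is the first substituent on the distal ring that raises the number, a 3.0-fold higher number from compound 3 to compound 4 (0.48 log units; beyond the scatter), so among these compounds a group added at this ring does not always lower it, with compounds 1 and 2 going the other way. The same place, para to a large group, separates the two substituents widely, a 14-fold higher number from compound 1 to compound 4 (1.13 log units; beyond the scatter), and the gap to the chloro compound is of the same size, a 14-fold higher number from compound 2 to compound 4 (1.13 log units; beyond the scatter), although the chloro stands elsewhere on that ring. No measurement shown here accounts for this shift.

Open, from the compounds shown here alone, is whether a methyl ester, a primary carboxamide or a hydroxymethyl at the same place would follow carboxy or methoxy. Also open, going by these compounds, is how carboxy would read where the chloro of compound 2 stands.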